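Swapping the 5-bromo-2-hydroxyphenyl group of compound 2 for thiophen-2-yl

The source may hold more compounds than are shown below. What is called first, only, known or untested is meant among the compounds shown, and "the series" means these compounds.

compound 1 (`O=C(CSc1nnc(-c2ccncc2)o1)N/N=C/c1ccccc1`): 22100 nM
compound 2 (`O=C(CSc1nnc(-c2ccncc2)o1)N/N=C/c1cc(Br)ccc1O`): 9590 nM

In a functional assay on BGC-823 cells (Homo sapiens) for cytotoxicity, read by MTT assay, with a stated time of 48 h (on this read-out lower numbers stand for stronger inhibition and higher numbers for weaker inhibition), compound 2 holds the lower of the two numbers (9590 nM). Compound 3 (`O=C(CSc1nnc(-c2ccncc2)o1)N/N=C/c1cccs1`) differs from it in one place (thiophen-2-yl in place of 5-bromo-2-hydroxyphenyl on a carbon with a double bond to nitrogen), with thiophen-2-yl in place of 5-bromo-2-hydroxyphenyl. For the measured compounds named here, only one measured step bears on this (a 2.3-fold lower number from compound 1 to compound 2 (0.36 log units; beyond the scatter)), a modest one beyond the scatter that brought in the group now leaving. Going by the values given here, no thiophen-2-yl compound has been measured, so a modest step of similar size toward a higher number is expected (a 2.1-fold higher number from compound 2 to compound 3 (0.32 log units; beyond the scatter)). Compound 3 is estimated at 20000 nM (expected range 8000 nM to 45000 nM).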

Compound 3, half-maximal inhibitory concentration: 26700 nM
Compound 3: middle estimate off by 1.3-fold (0.13 log units), on the low side, within the range that was stated.
By their numbers in this assay, from the lowest: compound 2; then compounds 1 and 3 (each within the scatter of the next).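

In this assay the thiophen-2-yl group does not hold the lower number seen with 5-bromo-2-hydroxyphenyl, giving a 2.8-fold higher number from compound 2 to compound 3 (0.44 log units; beyond the scatter) as the measured change, and it matches phenyl, giving a 1.2-fold higher number from compound 1 to compound 3 (0.08 log units; within the scatter) for that exchange. On a carbon with a double bond to nitrogen, these two plain aromatic rings therefore read alike, and only the 5-bromo-2-hydroxyphenyl compound stands apart. No evidence is available to explain this. The compounds shown leave open whether the bromine or the hydroxyl carries the step, and how a dimethylamino group or a carboxylic acid would read here.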